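Piperidin-3-yl in place of (piperazin-1-yl)methyl: working notes

This account rests on a few compounds, and the source may have more. Where it says the series, first, only, none or still open, it means among the compounds named here.

In an ADME assay on microsomes from liver (Mus musculus) for metabolic stability, read by LC-MS, with a stated time of 10 min, tested at 0.5 uM (on this read-out lower numbers stand for a less stable compound and higher numbers for a more stable compound), compound 1 `c1ccc2c(c1)CN[C@@H](CN(CC1CCNCC1)[C@H]1CCCc3cccnc31)C2` gives 13% and compound 2 `c1ccc2c(c1)CN[C@@H](CN(CCCN1CCNCC1)[C@H]1CCCc3cccnc31)C2` gives 92%, the higher of the two numbers. Compound 3 `c1ccc2c(c1)CN[C@@H](CN(CC[C@@H]1CCCNC1)[C@H]1CCCc3cccnc31)C2` departs from compound 2 as follows: piperidin-3-yl in place of (piperazin-1-yl)methyl on a saturated chain carbon, two bonds along the chain from an amine nitrogen. In words, piperidin-3-yl stands in place of (piperazin-1-yl)methyl on a saturated chain carbon, two bonds along the chain from an amine nitrogen. Going by the values given here, one measured step bears on this: a number 79 percentage points higher from compound 1 to compound 2 (beyond the scatter), a large step on exchanging piperidin-4-yl for 2-(piperazin-1-yl)ethyl. The new change also gives up the piperazin-1-yl group for a piperidine-named ring, but the ring position differs from compound 1, so that single step is only a loose guide. A large downward move is expected, a number 47 percentage points lower from compound 2 to compound 3 (beyond the scatter), likely stopping short of the full measured size. For compound 3 the expected value in this assay is 45%, with an estimated range of 12% to 82%.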

Compound 3, percent of the compound remaining: 23%
Compound 3: the middle estimate sits 22 percentage points above what was measured; low and high end bracket the measured number.
By their numbers in this assay, from the lowest: compounds 1 and 3 (each within the scatter of the next); then compound 2.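

In this assay, replacing (piperazin-1-yl)methyl with piperidin-3-yl on a saturated chain carbon, two bonds along the chain from an amine nitrogen, gives a number 69 percentage points lower from compound 2 to compound 3 (beyond the scatter): the high number of compound 2 does not survive this exchange. The two piperidine-bearing side chains are not separated, with (piperidin-3-yl)methyl in place of piperidin-4-yl giving a number 10 percentage points higher from compound 1 to compound 3 (within the scatter), so among these three compounds only the one carrying 2-(piperazin-1-yl)ethyl stands apart. No measurement at hand offers an explanation for this gap.

From the compounds shown here alone, it remains open whether the number of compound 2 depends on the piperazine ring itself or on a ring joined to the chain through its nitrogen. A 2-(piperidin-1-yl)ethyl or 2-(morpholin-4-yl)ethyl group at the same place would separate these two readings.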